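A few compounds are considered here, and "the series" means these few. Any claim that something is new, unique, unknown or untested is made for them only; others in the source may bear on it.

Working notes on the series.

Three compounds of the set carry numbers in an assay on isolated protein for inhibition of protein kinase C delta type (Homo sapiens), read by TR-FRET, with a stated time of 2 h; on this read-out lower numbers stand for stronger inhibition and higher numbers for weaker inhibition. Compound 1 `CO[C@H]1CC[C@@H](CNc2cc(NCc3cnccc3C(F)(F)F)ncc2C#N)CC1` gives 5000 nM, the highest of the three. Compound 3 `CC1(C)[C@H](O)C[C@H]1Nc1nc(NCc2cnccc2C(F)(F)F)ncc1C#N` gives 4500 nM, which sits within the scatter of the number for compound 1, so no order between these two can be read. Compound 2 `N#Cc1cnc(NCc2cnccc2C(F)(F)F)cc1N[C@H]1CC[C@@H](c2nc[nH]n2)CC1` gives 1200 nM, and its gap to compound 1 lies beyond the scatter, so compound 2 shows the stronger inhibition of the pair.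

Compound 4 `CC1(C)[C@@H](Nc2cc(NCc3cnccc3C(F)(F)F)ncc2C#N)C[C@H]1C(N)=O` has not been measured in this assay. It differs from compound 1 in one place: 3-carbamoyl-2,2-dimethylcyclobutyl in place of (4-methoxycyclohexyl)methyl on a nitrogen on an aromatic ring. Among the measured compounds shown here, the four-membered ring that enters is of the same kind as the ring carried by compound 3, though compound 3 sits on a different core and carries a hydroxyl in place of the carbamoyl, so no step that isolates this change is available among the measured compounds.

Given that compound 1 at 5000 nM and compound 3 at 4500 nM fall within the scatter of each other, the expectation for compound 4 is a step no larger than the scatter, if anything toward a lower number, as a 1.7-fold lower number from compound 1 to compound 4 (0.22 log units; within the scatter). Compound 4 is therefore estimated at 3000 nM, with a range of 800 nM to 12000 nM.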

Compound 4, half-maximal inhibitory concentration: 4500 nM
Beside the measured number, compound 4's estimate is 1.5-fold (0.18 log units) below it, and the stated range covers the measured number.
By their numbers in this assay, from the lowest: compound 2; then compounds 3, 4 and 1 (each within the scatter of the next).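

In this assay, among the compounds shown here, the replacement of (4-methoxycyclohexyl)methyl by 3-carbamoyl-2,2-dimethylcyclobutyl on a nitrogen on an aromatic ring gives the first single-place step, a 1.1-fold lower number from compound 1 to compound 4 (0.05 log units; within the scatter), so the numbers for these two compounds cannot be ordered. The exchange alters several features at once: a six-membered ring gives way to a four-membered ring, and a hydrogen-bond donor and a double bond outside aromatic rings enter, so this one step cannot assign any share of the outcome to a single feature. No measured evidence in hand bears on this result.

As far as these compounds go, what a carboxylic acid or an amine in place of the carbamoyl on the 2,2-dimethylcyclobutyl would give remains open. Also open, from the compounds shown here alone, is how the ring size reads alone, for instance with a carbamoyl carried on a cyclohexyl group at this same nitrogen.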